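Amide aryl variation on a shared flavonol-type core

The source may report more compounds than this note shows. Statements on the series, on what has been measured and on what is new or still open speak of the compounds shown alone.

In a functional assay on HeLa cells (Homo sapiens) for antiproliferative activity, read by CCK-8 assay, with a stated time of 72 h (on this read-out higher numbers stand for weaker inhibition and lower numbers for stronger inhibition), compound 2 `COc1ccc(C(=O)Nc2cccc(-c3oc4cc(-c5ccc(F)cc5)ccc4c(=O)c3O)c2)c(F)c1` gives 16100 nM. Compound 1 `CCc1ccc(C(=O)Nc2cccc(-c3oc4cc(-c5ccc(F)cc5)ccc4c(=O)c3O)c2)cc1` gives 21000 nM in this assay, and a 1.3-fold lower number from compound 1 to compound 2 (0.12 log units; within the scatter) leaves the two numbers within the scatter of one another, so neither is called stronger. Compound 3 `COc1cc(OC)cc(C(=O)Nc2cccc(-c3oc4cc(-c5ccc(F)cc5)ccc4c(=O)c3O)c2)c1` differs by 3,5-dimethoxyphenyl in place of 2-fluoro-4-methoxyphenyl on a carbonyl carbon. Within the data shown here, only the step from compound 1 to compound 2 bears on this change; it exchanged one aryl on the carbonyl for another and stayed within the scatter. A move of similar size is expected here, so a 1.1-fold higher number from compound 2 to compound 3 (0.02 log units; within the scatter) is estimated to stay within the scatter. Compound 3 is expected at 17000 nM, with a range of 7000 nM to 40000 nM.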

Compound 3, half-maximal inhibitory concentration: 2700 nM
The estimate for compound 3 lay 6.3-fold (0.80 log units) above the measured number, outside the stated range (below it).
By their numbers in this assay, from the lowest: compound 3; then compounds 2 and 1 (each within the scatter of the next).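

In this assay the aryl on the carbonyl carbon proves able to shift the read-out, with a 6.0-fold lower number from compound 2 to compound 3 (0.78 log units; beyond the scatter) and a 7.8-fold lower number from compound 1 to compound 3 (0.89 log units; beyond the scatter) against an earlier aryl exchange that stayed within the scatter. Compound 3 is thus the strongest of the three, though still modest in size of gain. No supporting data bear on why this aryl differs from the other two.
Open, as far as these compounds go, is whether both methoxy groups of 3,5-dimethoxyphenyl are needed. Also open, from the compounds shown here alone, is how 3,4,5-trimethoxyphenyl or a 3-aminophenyl on the same carbonyl would compare.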